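Methylsulfanyl for allyloxy: one swap on a shared core

The compounds below may be only part of what the source reports. "The series", "measured", "known", "first", "only" and "open" are said of these compounds alone.

In a functional assay on MCF7 cells (Homo sapiens) for antiproliferative activity, read by sulforhodamine B assay, with a stated time of 3 days (a higher number here means a weaker inhibitor, a lower number a stronger inhibitor), compound 1 `O=c1ccn(C2COc3ccccc3CO2)c(=O)[nH]1` gives 5000 nM and compound 2 `c1ccc2c(c1)COC(n1cnc3c(OCC4CCCCC4)ncnc31)CO2` gives 11600 nM while compound 3 `C=CCOc1ncnc2c1ncn2C1COc2ccccc2CO1` gives 5040 nM as its reading. Compound 3 and compound 1 lie within the scatter of each other and cannot be told apart, whereas the number for compound 2 stands clearly higher than both.

Still unmeasured is compound 4 `CSc1ncnc2c1ncn2C1COc2ccccc2CO1` which keeps the core of compound 3 and differs from it at one place. The change is methylsulfanyl in place of allyloxy on an aromatic carbon and in short it puts methylsulfanyl in place of allyloxy on an aromatic carbon.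

Going by the values given here, the only measured step that touches this group is a 2.3-fold lower number from compound 2 to compound 3 (0.36 log units; beyond the scatter) and it is modest. It put vinyl in place of cyclohexyl on a saturated chain carbon bound to an oxygen on an aromatic ring, so it altered the far end of the group and left the oxygen in place. Among the compounds with values here, no measured step replaces the whole group as compound 4 does, so the evidence is thin. Within the data shown here, with only that modest step from compound 2 to guide it, no step beyond the scatter is expected in this assay and the estimated change is a 1.0-fold lower number from compound 3 to compound 4 (0.00 log units; within the scatter) at this stage. For compound 4 the estimated value is 5000 nM with an expected range from 2000 nM to 12000 nM until a measurement arrives.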

Compound 4, half-maximal inhibitory concentration: 24000 nM
For compound 4 the middle estimate is 4.8-fold (0.68 log units) below the measured one, and the stated range ends below it.
By their numbers in this assay, from the lowest: compounds 1 and 3 (each within the scatter of the next); then compound 2; then compound 4.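

This swap replaces the whole group on the aromatic carbon rather than only its far end, and in this assay it gives a 4.8-fold higher number from compound 3 to compound 4 (0.68 log units; beyond the scatter) and so shows that the number does respond to what sits at this position. Methylsulfanyl also compares unfavourably with the larger oxygen-linked group, with a 2.1-fold higher number from compound 2 to compound 4 (0.32 log units; beyond the scatter) showing that the higher number is not confined to the comparison with allyloxy, so among these three compounds both groups attached through oxygen give lower numbers than the group attached through sulfur. The change puts sulfur in place of oxygen and also leaves a group of 2 heavy atoms in place of one of 4, and no accompanying measurement says why the number rises.

The compounds shown leave those two changes tangled, and methoxy, which pairs the oxygen link with a short chain, or allylsulfanyl, which pairs the sulfur link with the allyl end, would pull them apart. From the compounds shown here alone, how an amine on the same aromatic carbon would compare with either the oxygen-linked or the sulfur-linked groups also remains open.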